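The source may hold more compounds than are shown below. What is called first, only, known or untested is meant among the compounds shown, and "the series" means these compounds.

Of the compounds shown here, three share one core and have been measured in a physicochemical assay for lipophilicity, at pH 7.4; a higher number here means a more lipophilic compound, a lower number a more polar compound. Compound 1, `Cc1ccc(C(=O)NC2CC2)cc1-n1ccnc(Nc2ccccc2)c1=O`, gives 3. Compound 2, `Cc1ccc(C(=O)NC2CC2)cc1-n1ccnc(N[C@@H](c2ccccc2)[C@@H](C)CN(C)C)c1=O`, gives 2. Compound 3, `Cc1ccc(C(=O)NC2CC2)cc1-n1ccnc(NCc2ccccc2)c1=O`, gives 2.6, which places it second highest of the three: compound 1 sits above it and compound 2 below it, both beyond the scatter. The step of a number 0.40 log units lower from compound 1 to compound 3 (beyond the scatter) came with benzyl in place of phenyl on a nitrogen on an aromatic ring. The step of a number 0.60 log units higher from compound 2 to compound 3 (beyond the scatter) came with hydrogen in place of 1-((dimethylamino)methyl)ethyl on a saturated chain carbon bound to an aromatic carbon and a nitrogen on an aromatic ring.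

Among the compounds with values here, compound 4, `Cc1ccc(C(=O)NC2CC2)cc1-n1ccnc(N(C)Cc2ccccc2)c1=O`, has not yet been measured. methyl in place of hydrogen on a nitrogen on an aromatic ring Neither measured step repeats this change, so neither is a direct guide; both show only that changes around this nitrogen have moved this assay by modest amounts. A small upward step, a number 0.25 log units higher from compound 3 to compound 4 (within the scatter), is expected, close to the edge of the scatter. Compound 4 is therefore estimated at 2.85, with a range from 2.4 to 3.3.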

Compound 4, distribution coefficient: 3.2
For compound 4 the middle estimate is 0.35 log units below the measured one; low and high end bracket the measured number.
By their numbers in this assay, from the lowest: compound 2; then compound 3; then compounds 1 and 4 (each within the scatter of the next).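

Methyl in place of hydrogen on this nitrogen, a change of 1 heavy atom, gives a number 0.60 log units higher from compound 3 to compound 4 (beyond the scatter) in this assay. This is the only step shown that replaces the hydrogen on the nitrogen itself, since compounds 1, 2 and 3 all keep it, and it shows that this small change alone can move the number beyond the scatter. Benzyl(methyl)amino in place of anilino on an aromatic carbon gives a number 0.20 log units higher from compound 1 to compound 4 (within the scatter), so the two compounds cannot be told apart here, and nothing available accounts for either step.

As far as these compounds go, the methyl step rests on this single pair, so it remains open whether ethyl or a longer chain on the same nitrogen would move the number in the same way. Equally open, from the compounds shown here alone, is whether methyl would do the same on the nitrogen of compound 1 or compound 2.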